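This account rests on a few compounds, and the source may have more. Where it says the series, first, only, none or still open, it means among the compounds named here.

Working notes on the series. The shared core is that of compound 1 `CCOC(=O)CC(=O)Nc1c(C(C)C)cccc1C(C)C`; only the ester chain varies. In an assay on microsomes from intestine for inhibition of acyl-CoA:cholesterol acyltransferase (Oryctolagus cuniculus) (on this read-out higher numbers stand for weaker inhibition and lower numbers for stronger inhibition), compound 1 gives 1800 nM. Compound 3 `CCCCCCCCCCCCOC(=O)CC(=O)Nc1c(C(C)C)cccc1C(C)C` gives 11 nM, and compound 2 `CCCCCCCCCCCC[C@H](C)OC(=O)CC(=O)Nc1c(C(C)C)cccc1C(C)C` gives 4 nM. Compound 3 thus stands second highest of the three numbers, beyond the scatter from both of the others: compound 2 lies lower, compound 1 far higher. Among the compounds with values here, the only step between compounds differing in one place is a 160-fold lower number from compound 1 to compound 3 (2.21 log units; beyond the scatter), which ties the length of the ester chain to the read-out. Compound 4 `CCCCCCCCCCCCCCCCCCOC(=O)CC(=O)Nc1c(C(C)C)cccc1C(C)C` is not yet measured; it differs from compound 3 by hexyl in place of hydrogen on a saturated chain carbon, ten or more bonds along the chain from an oxygen next to a carbonyl group. Within the data shown here, the measured step bears on it only loosely, since there a chain was added where none stood, whereas here an already long chain is extended at its far end, and no measured pair covers such an extension. A small change at most is expected, a 1.4-fold higher number from compound 3 to compound 4 (0.13 log units; within the scatter). The value for compound 4 is estimated at 15 nM, with a range from 4 nM to 60 nM.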

Compound 4, half-maximal inhibitory concentration: 53 nM
Compound 4: the middle estimate sits 3.5-fold (0.55 log units) below what was measured; measured number inside the range.
By their numbers in this assay, from the lowest: compound 2; then compound 3; then compound 4; then compound 1.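

Hexyl in place of hydrogen on a saturated chain carbon is not a silent change in this assay: it gives a 4.8-fold higher number from compound 3 to compound 4 (0.68 log units; beyond the scatter). This runs opposite to a 160-fold lower number from compound 1 to compound 3 (2.21 log units; beyond the scatter), so the read-out does not keep falling as the ester chain grows, and of compound 1, compound 3 and compound 4, compound 3 has the lowest number. Nothing at hand accounts for this reversal.

On these data alone, whether chains of intermediate length give numbers below that of compound 3, and whether a longer chain raises the number further, stays open. Also open, as far as these compounds go, is how a carboxylic acid or an amine in place of hexyl would read in this assay.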